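The source may hold more compounds than are shown below. What is called first, only, known or untested is meant among the compounds shown, and "the series" means these compounds.

Working notes on the series. Compound 1 `COc1cc(OC)cc(-c2cn(-c3cc(OC)c(OC)c(OC)c3)nn2)c1` and compound 2 `COc1cc(OC)cc(-c2cn(-c3ccc(OC)c(OC)c3)nn2)c1` differ by one methoxy group; compound 3 `COc1ccc(-n2cc(-c3cc(O)cc(O)c3)nn2)cc1` carries two hydroxy groups on its other ring, and compound 4 `COc1ccc(-n2cc(-c3cc(O)cc(O)c3)nn2)cc1OC` is its unmeasured analogue. In a functional assay on MDA-MB-231 cells (Homo sapiens) for cytotoxicity, read by MTT assay (a higher number here means a weaker inhibitor, a lower number a stronger inhibitor), compound 2 gives 10000 nM. For compound 1 this assay reports only a limit, > 10000 nM. For compound 3 it likewise reports only a limit, > 10000 nM. The step of a number no lower from compound 2 to compound 1 (the limit leaves the size open) is the change (methoxy in place of hydrogen on an aromatic carbon); its size cannot be read because the limit of > 10000 nM in this assay, at which 2 of the 3 values shown sit, caps the value of compound 1. The difference between the cores of compound 2 and compound 3 is not broken down here. The change from compound 3 to compound 4 is methoxy in place of hydrogen on an aromatic carbon, the same kind of change, though not the same: in compound 1 the place is also meta to a methoxy group, which it is not in compound 4. Among the compounds with values here, only one measured instance of this change exists, and it is bounded by a limit, so no size is known. Within the data shown here, the step from compound 3 to compound 4 is expected to be small, a step that the limit leaves unreadable from compound 3 to compound 4, as the only precedent a number no lower from compound 2 to compound 1 (the limit leaves the size open) shows no gain. For compound 4 the expected value in this assay is 12000 nM, most likely again reported as a limit.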

Compound 4, half-maximal inhibitory concentration: > 10000 nM
Compound 4: no number, only a limit (the forecaster's own chance of this, stated with the estimate: 70%); the middle value is on the limit's open side.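

No new step can be read: compound 3 and compound 4 are both reported only as limits in this assay, so the change between them has no readable size: the limit of > 10000 nM in this assay, at which 3 of the 4 values shown sit.

The compounds shown leave open where the true values of compound 1, compound 3 and compound 4 lie, and whether methoxy in place of hydrogen on an aromatic carbon changes the read-out at all.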